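From nitro to trifluoromethyl on an aromatic carbon

The compounds below may be only part of what the source reports. "The series", "measured", "known", "first", "only" and "open" are said of these compounds alone.

Measured so far in a functional assay on HeLa cells (Homo sapiens) for antiproliferative activity, read by MTT assay, with a stated time of 24 h; a lower number here means a stronger inhibitor, a higher number a weaker inhibitor:
compound 1 `Cc1ccc(/C=N/c2ccccc2)c(C)c1` gives 115000 nM
compound 2 `O=[N+]([O-])c1ccc(/C=N/c2ccccc2)cc1` gives 165000 nM

Only these two values are available, and they lie within the usual scatter of each other. Compound 2 at 165000 nM therefore cannot be ranked against compound 1 at 115000 nM in either direction.

The next compound, compound 3 `FC(F)(F)c1ccc(/C=N/c2ccccc2)cc1`, has not yet been measured. It keeps the core of compound 2 but carries trifluoromethyl in place of nitro on an aromatic carbon. Neither group forms a ring or carries a net charge. For the measured compounds named here, no measured pair shows this exchange, so the data offer no direct guide to its size. The only indication is how close compound 2 at 165000 nM stands to compound 1 at 115000 nM in this assay.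

The change expected is a 1.2-fold lower number from compound 2 to compound 3 (0.07 log units; within the scatter) and it is expected to stay within the scatter, in neither direction. For compound 3 the estimated half-maximal inhibitory concentration is 140000 nM (expected range 70000 nM to 280000 nM).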

Compound 3, half-maximal inhibitory concentration: 1900 nM
Beside the measured number, compound 3's estimate is 74-fold (1.87 log units) above it; the whole stated range lies above it.
By their numbers in this assay, from the lowest: compound 3; then compounds 1 and 2 (each within the scatter of the next).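

In this assay, trifluoromethyl in place of nitro on an aromatic carbon, para to a group of 8 heavy atoms, gives an 87-fold lower number from compound 2 to compound 3 (1.94 log units; beyond the scatter), which shows that this position responds strongly to the group it carries, something the two earlier values, lying within the scatter of each other, gave no sign of. The exchange is a small one by count: both groups are without a ring and without net charge, and neither has a hydrogen-bond donor, while the double bond and the hydrogen-bond acceptors of nitro are absent from trifluoromethyl, so a modest change in structure is enough here for a large change in the number. No measurement at hand bears on which feature of the two groups accounts for this step.

The compounds shown leave open whether the low number belongs to trifluoromethyl alone or extends to other groups at this position, such as a single fluorine, a chlorine, a nitrile, a methoxy group or a carboxylic acid. They also leave open whether the same exchange would have a comparable effect at another aromatic carbon of the shared core.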